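Swapping a Triazole for a Pyridine in Compound 1

The source may hold more compounds than are shown below. What is called first, only, known or untested is meant among the compounds shown, and "the series" means these compounds.

compound 1, `CCN(Cc1c[nH]nn1)C(=O)COc1ccc(C)cc1`: 31100 nM
compound 2, `CCCc1ccc(OCC(=O)N(CC)Cc2cccs2)cc1`: 1810 nM
compound 3, `Cc1ccc(OCC(=O)N(Cc2cccs2)c2ccnn2C)cc1`: 422 nM

All three were measured in an assay on HEK293 cells for agonist activity at transient receptor potential cation channel subfamily M member 8 (Homo sapiens), read by fluorescence and calcium flux, with a stated time of 15 min; on this read-out higher numbers stand for an effect only at larger amounts of compound and lower numbers for an effect already at smaller amounts. Compound 1 gives the highest of the three numbers and is the weakest: compound 2 sits a step below it that lies beyond the usual scatter, and compound 3 lies further still. Compound 4, `CCN(Cc1ccncc1)C(=O)COc1ccc(C)cc1`, is not yet measured. It differs from compound 1 in one place: pyridin-4-yl in place of 1H-1,2,3-triazol-4-yl on a saturated chain carbon bound to an amide-type nitrogen. Compound 2, at 1810 nM, and compound 3, at 422 nM, both carry a ring without a hydrogen-bond donor on the saturated chain carbon bound to the amide-type nitrogen. Compound 4 is expected to improve by a moderate step, a 3.9-fold lower number from compound 1 to compound 4 (0.59 log units; beyond the scatter). The estimate for compound 4 is 8000 nM, within 2500 nM to 25000 nM.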

Compound 4, half-maximal effective concentration: "not active" (no number reported)
For compound 4 the study gives words and no number; the estimate stays without a comparison.
By their numbers in this assay, from the lowest: compound 3; then compound 2; then compound 1.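

Among the compounds shown here, compound 4 is reported in words only, as not active, and no step from compound 1 to compound 4 can be read. The compounds shown leave open how far pyridin-4-yl in place of 1H-1,2,3-triazol-4-yl shifts the number. No measured evidence bears on a cause.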